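A Third Ring Variant on the Shared Core

This account rests on a few compounds, and the source may have more. Where it says the series, first, only, none or still open, it means among the compounds named here.

Of the compounds shown here, three built on one shared core have been tested in a functional assay on NCI-H460 cells (Homo sapiens) for cytotoxicity, read by MTT assay, with a stated time of 72 h; a lower number here means a stronger inhibitor, a higher number a weaker inhibitor. Compound 1 `CN(C)CCn1cnnc1-c1cc(Oc2ccc(NC(=O)N/N=C/c3cccc(O)c3)cc2F)ccn1` gives 780 nM. Compound 2 `CN(C)CCn1cnnc1-c1cc(Oc2ccc(NC(=O)N/N=C/c3ccc(F)cc3Cl)cc2F)ccn1` gives 720 nM, and compound 3 `CN(C)CCn1cnnc1-c1cc(Oc2ccc(NC(=O)N/N=C/c3ccccc3O[N+](=O)[O-])cc2F)ccn1` gives 1270 nM. Compound 1 therefore stands second highest of the three numbers, yet all three lie within the scatter of one another: the step of a 1.1-fold lower number from compound 1 to compound 2 (0.03 log units; within the scatter) and the step of a 1.6-fold higher number from compound 1 to compound 3 (0.21 log units; within the scatter) are both within the scatter, as is the step of a 1.8-fold higher number from compound 2 to compound 3 (0.25 log units; within the scatter).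

Compound 4 `Cc1cc(/C=N/NC(=O)Nc2ccc(Oc3ccnc(-c4nncn4CCN(C)C)c3)c(F)c2)cc(C)c1O` differs from compound 1 only in the ring that sits on the carbon with a double bond to nitrogen: 4-hydroxy-3,5-dimethylphenyl in place of 3-hydroxyphenyl on a carbon with a double bond to nitrogen.

The two measured steps that start from compound 1 bear directly on this change, since each of them also exchanged that same ring for a different one, and neither moved the number beyond the scatter. Going by the values given here, nothing among the measured compounds shows that this ring shifts the result, so for compound 4 the expectation is no step beyond the scatter in this assay, a 1.0-fold higher number from compound 1 to compound 4 (0.01 log units; within the scatter). Compound 4 is thus estimated at 800 nM, with a range from 350 nM to 1800 nM.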

Compound 4, half-maximal inhibitory concentration: 2010 nM
Compound 4: the middle estimate sits 2.5-fold (0.40 log units) below what was measured; the measured number lies above the stated range.
By their numbers in this assay, from the lowest: compounds 2, 1, 3 and 4 (each within the scatter of the next, the first and the last beyond it).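

In this assay this position now shows that the choice of ring can matter: the earlier ring exchanges all stayed within the scatter, whereas 4-hydroxy-3,5-dimethylphenyl gives a 2.6-fold higher number from compound 1 to compound 4 (0.41 log units; beyond the scatter) and a 2.8-fold higher number from compound 2 to compound 4 (0.45 log units; beyond the scatter), both modest steps, while a 1.6-fold higher number from compound 3 to compound 4 (0.20 log units; within the scatter) does not separate those two compounds. Going from 3-hydroxyphenyl to 4-hydroxy-3,5-dimethylphenyl both adds two methyl groups and changes the ring position of the hydroxy group, so this single exchange cannot show which of the two goes with the step. No supporting data are at hand to explain the result.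

The compounds shown leave open whether the two methyl groups or the changed hydroxy position goes with the step, a question that 4-hydroxyphenyl and 3,5-dimethylphenyl on the same carbon could help to separate. They also leave open how a ring carrying an amine or a carboxylic acid would read at this position.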